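A few compounds are considered here, and "the series" means these few. Any claim that something is new, unique, unknown or untested is made for them only; others in the source may bear on it.

Measured compounds in a functional assay on A-375 cells (Homo sapiens) for cytotoxicity, read by MTT assay, with a stated time of 72 h, tested at 1 uM; on this read-out higher numbers stand for more inhibition of growth at the one concentration tested and lower numbers for less inhibition of growth:
compound 1 `N/C(=N\NC(=S)N1CCSCC1)c1ccccn1`, 34%
compound 2 `N/C(=N\NC(=S)N1CCOCC1)c1ccc(F)cn1`, 44.5%
compound 3 `N/C(=N\NC(=S)N1CCOCC1)c1ccccn1`, 26.8%

Compound 3 gives the lowest of the three numbers in this assay, but the step of a number 7.2 percentage points lower from compound 1 to compound 3 (within the scatter) is within the scatter, so compound 1 and compound 3 cannot be told apart on these data; only compound 2 stands beyond the scatter, as the step of a number 17.7 percentage points lower from compound 2 to compound 3 (beyond the scatter) shows.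

Compound 4 `Cc1ccnc(/C(N)=N/NC(=S)N2CCOCC2)c1` differs from compound 3 by methyl in place of hydrogen on an aromatic carbon. Within the data shown here, no measured step puts a methyl group onto the shared core, so no step bears on this change directly. Among the measured compounds shown here, the only step at an aromatic carbon of the ring, a number 17.7 percentage points lower from compound 2 to compound 3 (beyond the scatter), shows that a substituent there can shift the number modestly, yet fluoro and methyl are different groups, and the direction for methyl cannot be read from it. The expectation for compound 4 is therefore a small rise at most, a number 5.2 percentage points higher from compound 3 to compound 4 (within the scatter), not clearly beyond the scatter. Compound 4 is estimated at 32%, within a range of 18% to 48%.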

Compound 4, percent growth inhibition at one concentration: 43.2%
For compound 4 the middle estimate is 11.2 percentage points below the measured one; the measured number falls inside the stated range.
By their numbers in this assay, from the lowest: compounds 3, 1, 4 and 2 (each within the scatter of the next, the first and the last beyond it).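

The step of a number 16.4 percentage points higher from compound 3 to compound 4 (beyond the scatter) in this assay shows that this position, opposite the ring nitrogen, responds to a group of a single carbon. Until now the only change on the ring was fluoro, seen in the step of a number 17.7 percentage points lower from compound 2 to compound 3 (beyond the scatter), and methyl now also gives a number beyond the scatter above that of compound 3, so among these compounds both ring substituents read higher than hydrogen. Nothing available explains why the methyl group has this effect.

The compounds shown leave open whether the rise is particular to methyl or would also come with an ethyl chain, a methoxy group or an amine at the same place. They also leave open whether methyl would give a similar step on compound 1, which carries thiomorpholin-4-yl in place of morpholin-4-yl.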